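Swapping Fluoro for Dimethylamino on a Shared Core

A few compounds are considered here, and "the series" means these few. Any claim that something is new, unique, unknown or untested is made for them only; others in the source may bear on it.

Compound 1 `O=C1/C(=C/c2ccc(F)cc2)Cc2cc(O)ccc21` was examined in an assay on isolated protein for inhibition of Amine oxidase [flavin-containing] A (Homo sapiens), read by fluorescence and spectrophotometry, with a stated time of 20 min (on this read-out lower numbers stand for stronger inhibition and higher numbers for weaker inhibition), where compound 1 gives 679 nM. A second member of the series, compound 2 `COc1cccc(/C=C2\Cc3cc(O)ccc3C2=O)c1`, carries a methoxy group in place of the fluoro and in this assay compound 2 gives 1190 nM. Among the measured compounds shown here, of the two numbers recorded, compound 1 stands at the end with the smaller value, with compound 2 as its only neighbour, and the gap between them lies within the usual scatter, so the two compounds cannot be told apart on these data.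

Compound 3 `CN(C)c1ccc(/C=C2\Cc3cc(O)ccc3C2=O)cc1` is the next variation on the core of compound 1. The change is dimethylamino in place of fluoro on an aromatic carbon, in words: dimethylamino in place of fluoro on an aromatic carbon. For the measured compounds named here, no pair of measured compounds shows a step of this kind, so there is no direct precedent. Given that compound 1 at 679 nM and compound 2 at 1190 nM sit so close together, a step of modest size in either direction, or none beyond the scatter, is expected, and the step from compound 1 to compound 3 is estimated at a 1.2-fold higher number from compound 1 to compound 3 (0.07 log units; within the scatter). For compound 3 the expected value in this assay is 800 nM, within a range from 300 nM to 2500 nM.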

Compound 3, half-maximal inhibitory concentration: 1720 nM
Beside the measured number, compound 3's estimate is 2.2-fold (0.33 log units) below it, within the range that was stated.
By their numbers in this assay, from the lowest: compounds 1, 2 and 3 (each within the scatter of the next, the first and the last beyond it).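

At this position, on an aromatic carbon para to a large group, exchanging fluoro for dimethylamino gives a step that can be read beyond the scatter in this assay: a 2.5-fold higher number from compound 1 to compound 3 (0.40 log units; beyond the scatter). The step is modest, so the larger group, with its 3 heavy atoms and 1 hydrogen-bond acceptor against the 1 heavy atom of fluoro, costs some inhibition, yet compound 3 still gives a measurable 1720 nM. No measurement at hand indicates which feature of the exchange lies behind this step.

The compounds shown leave open whether a plain amino group or a carboxylic acid on this same aromatic carbon would move the number in the same direction, and how far. They also leave open whether the step belongs to this position alone, since dimethylamino appears here on only one aromatic carbon of the shared core, and a single step cannot show whether the same exchange would have a similar effect elsewhere on it.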